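The source may hold more compounds than are shown below. What is called first, only, known or untested is meant among the compounds shown, and "the series" means these compounds.

- Compound 1 (`CC(C)n1cnc2c(NC(=N)N)nc(N)nc21`) gives 97200 nM
- Compound 2 (`CC(C)Cn1cnc2c(NC(=N)N)nc(N)nc21`) gives 96600 nM

Both numbers come from a functional assay on MCF7 cells (Homo sapiens) for inhibition, read by fluorescence, with a stated time of 72 h (on this read-out lower numbers stand for stronger inhibition and higher numbers for weaker inhibition), and cannot be told apart, so compound 2 stands level with compound 1. Compound 3 (`CCn1cnc2c(NC(=N)N)nc(N)nc21`) differs from compound 2 by methyl in place of isopropyl on a saturated chain carbon bound to an aromatic nitrogen which, cut one bond further out, reads isobutyl to ethyl. For the measured compounds named here, only one measured step bears on this (a 1.0-fold lower number from compound 1 to compound 2 (0.00 log units; within the scatter)) and it also alters that chain, staying within the scatter. An estimated step (a 1.0-fold lower number from compound 2 to compound 3 (0.01 log units; within the scatter)) within the scatter is therefore expected, in neither direction. Compound 3 is expected in this assay at 95000 nM with a range of 50000 nM to 180000 nM as the estimate.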

Compound 3, half-maximal inhibitory concentration: 54300 nM
Estimate against measurement, compound 3: 1.7-fold (0.24 log units) above, within the range that was stated.
By their numbers in this assay, from the lowest: compounds 3, 2 and 1 (each within the scatter of the next).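

Swapping the chain on this aromatic nitrogen for ethyl gives, in this assay, a 1.8-fold lower number from compound 2 to compound 3 (0.25 log units; within the scatter) and a 1.8-fold lower number from compound 1 to compound 3 (0.25 log units; within the scatter), so this position has now held isopropyl, isobutyl and ethyl. Even the change from isobutyl to ethyl, which removes more of the chain than the earlier step did, stays inside what repeat measurements could give. Nothing available explains these numbers. As far as these compounds go, what a longer chain, a benzyl group or a carboxylic acid at this nitrogen would give stays open, as does whether any group there moves the number beyond the scatter.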